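The source may report more compounds than this note shows. Statements on the series, on what has been measured and on what is new or still open speak of the compounds shown alone.

Working notes, series of compounds sharing one core.

Among the compounds with values here, compound 1 `C[C@H](NC(=O)CN(c1nc(Cl)nc2[nH]cnc12)C1CC1)C(=O)OCc1ccccc1` and compound 2 `O=C(CN(c1nc(Cl)nc2[nH]cnc12)C1CC1)NCC(=O)OCc1ccccc1` are the two measured members. In a functional assay on the whole organism (Tail, strain ICR) with Mus musculus as the target, in the tail flick test, with a stated time of 30 min, at a dose of 25 umol/kg by the oral route (a higher number here means a stronger effect of the compound at the dose given, a lower number a weaker effect), compound 1 gives 41.2% and compound 2 gives 18.7%. Within the data shown here, the single step between them, a number 22.5 percentage points lower from compound 1 to compound 2 (beyond the scatter), puts compound 2 at the lower of the two numbers, and the gap to compound 1 exceeds the scatter.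

Compound 3 `O=C(O)CNC(=O)CN(c1nc(Cl)nc2[nH]cnc12)C1CC1` is not yet measured. It differs from compound 2 by hydrogen in place of benzyl on an oxygen next to a carbonyl group, the difference cut one bond further out reading as benzyloxy to hydroxy. Among the measured compounds shown here, no measured step involves this position: the only step recorded, from compound 1 to compound 2, concerns the saturated chain carbon and not the oxygen next to the carbonyl group. Nothing in the numbers therefore fixes the direction or size of the change in this assay, and the expectation rests on compound 2 alone, with wide bounds. Compound 3 is estimated at 15%, within 0% to 40%, the step from compound 2 being an expected a number 3.7 percentage points lower from compound 2 to compound 3 (within the scatter).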

Compound 3, a percentage reported as activity, at one dose (the size of the read-out at that dose, not a potency): 32.2%
Beside the measured number, compound 3's estimate is 17.2 percentage points below it; the measured number falls inside the stated range.
By their numbers in this assay, from the lowest: compound 2; then compounds 3 and 1 (each within the scatter of the next).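

In this assay, the oxygen next to a carbonyl group now has a reading of its own: hydrogen in place of benzyl gives a number 13.5 percentage points higher from compound 2 to compound 3 (beyond the scatter). Within the data shown here, earlier, the only recorded step concerned the saturated chain carbon, so this is the first sign that the benzyloxy to hydroxy change registers in this assay, and that compound 3 keeps a reading of 32.2% without the benzyl group and its six-membered aromatic ring of carbon only. Nothing available bears on the reason for this rise.

The compounds shown leave open whether the rise depends on removing the whole benzyl group, since a smaller group such as methyl or ethyl on the same oxygen would separate that question from the presence of hydroxy itself. They also leave open whether benzyloxy to hydroxy reads the same way on the methyl-bearing chain of compound 1, and how a primary amide in place of the hydroxy would compare at this dose.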